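Aryl swap at the same carbon; solubility of compound 3

This account rests on a few compounds, and the source may have more. Where it says the series, first, only, none or still open, it means among the compounds named here.

Compound 2 `Cn1nccc1-c1cc(C(F)(F)F)ccc1[C@H]1CCOc2cc(S(=O)(=O)Nc3nccs3)ccc21` gives 83000 nM in a physicochemical assay for solubility (on this read-out lower numbers stand for lower solubility and higher numbers for higher solubility), the highest of the two numbers in hand; its nearest neighbour is compound 1 `O=S(=O)(Nc1nccs1)c1ccc2c(c1)OCC[C@@H]2c1ccc(C(F)(F)F)cc1-c1ccc(F)cn1`, which gives 7000 nM in this assay. Within the data shown here, the one measured step, a 12-fold higher number from compound 1 to compound 2 (1.07 log units; beyond the scatter), accompanied the change 1-methyl-1H-pyrazol-5-yl in place of 5-fluoropyridin-2-yl on an aromatic carbon. Compound 3 `O=S(=O)(Nc1nccs1)c1ccc2c(c1)OCC[C@@H]2c1ccc(C(F)(F)F)cc1-c1nccs1` is not yet measured in this assay. Its difference from compound 2: 1,3-thiazol-2-yl in place of 1-methyl-1H-pyrazol-5-yl on an aromatic carbon. Among the measured compounds shown here, the step from compound 1 to compound 2 bears on this only indirectly: it shows that exchanging the aromatic ring on this carbon, ortho to a large group and meta to a trifluoromethyl group, can move this assay by a large amount, but no measured pair involves 1,3-thiazol-2-yl. A partial return toward the number of compound 1 is expected, so a moderate fall a 3.3-fold lower number from compound 2 to compound 3 (0.52 log units; beyond the scatter) is estimated, with a wide range. Compound 3 is expected to give about 25000 nM in this assay, between 7000 nM and 85000 nM.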

Compound 3, solubility: 15000 nM
Estimate against measurement, compound 3: 1.7-fold (0.22 log units) above; measured number inside the range.
By their numbers in this assay, from the lowest: compound 1; then compound 3; then compound 2.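

In this assay, this aromatic carbon, ortho to a large group, now has three rings compared, and the number depends on more than ring size or the counted hydrogen-bond donors and acceptors: a 5.5-fold lower number from compound 2 to compound 3 (0.74 log units; beyond the scatter) with 1,3-thiazol-2-yl in place of 1-methyl-1H-pyrazol-5-yl, although both are five-membered aromatic rings with the same counts. The other step, a 2.1-fold higher number from compound 1 to compound 3 (0.33 log units; beyond the scatter) with 1,3-thiazol-2-yl in place of 5-fluoropyridin-2-yl, places compound 3 between the two earlier compounds, so a five-membered ring here does not by itself reach the number of compound 2. Nothing available accounts for this order of the three rings.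

Open questions are how an amine or a carboxylic acid on this carbon would compare with these aromatic rings, and whether the same order would hold with the trifluoromethyl group replaced by a nitrile.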